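Trifluoromethyl for chloro on a sulfonamide-bearing aryl ring

The compounds below may be only part of what the source reports. "The series", "measured", "known", "first", "only" and "open" are said of these compounds alone.

Compound 1, `CCC(C)(C)NS(=O)(=O)c1ccc(-c2sc(C(=O)N[C@H]3C[C@H](C(=O)O)C3)nc2CC2CCCCC2)c(Cl)c1C`, in a physicochemical assay for solubility, read by HPLC, in phosphate buffer, measured as thermodynamic solubility, with a stated time of 5 days, at pH 2, tested at 10 mM (on this read-out lower numbers stand for lower solubility and higher numbers for higher solubility), gives < 1000 nM, which is a limit of the assay and not a number.
Compound 2, `CC(C)(C)NS(=O)(=O)c1ccc(-c2sc(C(=O)N[C@H]3C[C@H](C(=O)O)C3)nc2CC2CCCCC2)c2c1CCCC2`, gives in this assay the value < 1000 nM, again a limit.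
Compound 3, `CC(C)(C)NS(=O)(=O)c1ccc(-c2sc(C(=O)N[C@H]3C[C@H](C(=O)O)C3)nc2CC2CCCCC2)c(Cl)c1`, gives in this assay the value < 1000 nM, also a limit.

All three measured compounds thus sit at the same place, described by the limit of < 1000 nM in this assay, at which 3 of the 3 values shown sit. Compound 3 therefore stands nowhere that can be ranked: its value is a limit, and the two further values are limits as well, so no order among the three can be read from the numbers.

Compound 4, `CC(C)(C)NS(=O)(=O)c1ccc(-c2sc(C(=O)N[C@H]3C[C@H](C(=O)O)C3)nc2CC2CCCCC2)c(C(F)(F)F)c1`, differs from compound 3 in one place: trifluoromethyl in place of chloro on an aromatic carbon. Among the measured compounds shown here, no step between two measured compounds is known here, so nothing measured indicates how large a step this exchange produces. With every measured value resting at the limit, the step that the limit leaves unreadable from compound 3 to compound 4 is expected to be none beyond the usual scatter, in the sense that compound 4 is expected to report a limit too. Compound 4 is estimated at 400 nM, with a range from 80 nM to 1500 nM.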

Compound 4, solubility: < 4000 nM
Compound 4 was reported as a limit (the forecaster's own chance of this, stated with the estimate: 80%); the middle value does not contradict the limit.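

In this assay compound 3 gives < 1000 nM, which is a limit. Compound 4 gives < 4000 nM, also a limit, so no step can be read between compound 3 and compound 4. The compounds shown leave open the actual solubility of all four compounds, and whether trifluoromethyl in place of chloro on an aromatic carbon changes it at all.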